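This account rests on a few compounds, and the source may have more. Where it says the series, first, only, none or still open, it means among the compounds named here.

Measured in a functional assay on MCF7 cells (Homo sapiens) for inhibition, read by MTT assay, with a stated time of 48 h, tested at 10 uM; a lower number here means less inhibition of growth, a higher number more inhibition of growth at the concentration tested:
- compound 1 `Cc1oc2c([C@H]3CCN(C)C[C@H]3O)c(O)cc(O)c2c(=O)c1C(O)c1ccc([N+](=O)[O-])cc1`: 4%
- compound 2 `CN1CC[C@H](c2c(O)cc(O)c3c(=O)cc(/C=C/c4ccccc4)oc23)[C@H](O)C1`: 8%
- compound 3 `CN1CC[C@H](c2c(O)cc(O)c3c(=O)cc(/C=C/c4c(F)c(F)c(F)c(F)c4F)oc23)[C@H](O)C1`: 64%

Compound 3 stands highest of the three, beyond the scatter above both others. Compound 4 `CN1CC[C@H](c2c(O)cc(O)c3c(=O)cc(/C=C/c4ccccc4Cl)oc23)[C@H](O)C1` alters one group of compound 3: 2-chlorophenyl in place of 2,3,4,5,6-pentafluorophenyl on a double-bonded chain carbon bound to a double-bonded chain carbon. Going by the values given here, only one measured step concerns this place, and it is large: a number 56 percentage points higher from compound 2 to compound 3 (beyond the scatter). Among the compounds with values here, no measured compound carries chlorine, so the data cannot say directly how a 2-chlorophenyl group behaves. It is neither the phenyl of compound 2 nor the pentafluorophenyl of compound 3, so a partial loss of that large rise seems likely. A clear drop is expected in this assay, an estimated a number 39 percentage points lower from compound 3 to compound 4 (beyond the scatter). For compound 4 the estimated value is 25%, with an expected range from 8% to 55%.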

Compound 4, percent growth inhibition at one concentration: 63%
Beside the measured number, compound 4's estimate is 38 percentage points below it, outside the stated range (above it).
By their numbers in this assay, from the lowest: compounds 1 and 2 (each within the scatter of the next); then compounds 4 and 3 (each within the scatter of the next).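

In this assay, chloro in place of hydrogen on an aromatic carbon is enough for a large rise: a number 55 percentage points higher from compound 2 to compound 4 (beyond the scatter). Against the pentafluorophenyl compound, the step is a number 1 percentage points lower from compound 3 to compound 4 (within the scatter), so at this place 2-chlorophenyl and 2,3,4,5,6-pentafluorophenyl cannot be told apart, and full fluorine substitution of the ring is not required for this level of growth inhibition. Nothing available explains this match. Still open, as far as these compounds go, is whether a single fluoro, a methoxy or an amine on this phenyl ring would give such a rise, and whether chloro would do so elsewhere on the ring.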